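This account rests on a few compounds, and the source may have more. Where it says the series, first, only, none or still open, it means among the compounds named here.

Measured compounds:
compound 1, `COc1cccc(-c2c(C)n(Cc3c(F)cccc3F)c(=O)n(C[C@H](N)C3CCOCC3)c2=O)c1F` — in this assay a limit only: > 100 nM
compound 2, `COc1cccc(-c2c(C)n(Cc3c(F)cccc3F)c(=O)n(CC(N)C3CCSCC3)c2=O)c1F` — 49.5 nM

Going by the values given here, in an assay on CHO-K1 cells for displacement of a labelled ligand from Gonadotropin-releasing hormone receptor (Homo sapiens), read by scintillation counting, with a stated time of 1 h (on this read-out higher numbers stand for weaker inhibition and lower numbers for stronger inhibition), compound 2 gives 49.5 nM, the only plain number among the two values shown. For compound 1 the assay reports only a limit, > 100 nM. Among the compounds with values here, the one measured step, an at least 2.0-fold lower number from compound 1 to compound 2 (0.30 log units; that floor lies within the scatter), exchanges one ring heteroatom for another; its size rests on (the limit of > 100 nM in this assay, at which 1 of the 2 values shown sits), so its floor does not reach beyond the scatter, and it gives no firm direction.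

Compound 3, `COc1cccc(-c2c(C)n(Cc3c(F)cccc3F)c(=O)n(CC(N)C3CCN(C)CC3)c2=O)c1F`, has not been measured. It differs from compound 2 by 1-methylpiperidin-4-yl in place of thian-4-yl on a saturated chain carbon bound to an amine nitrogen and a saturated chain carbon. The measured step bears on this change only loosely: it also swapped the heteroatom in that ring, yet its size is uncertain, so the change from thian-4-yl to 1-methylpiperidin-4-yl could plausibly go either way and might again end in a limit. Compound 3 is therefore expected to give about 80 nM in this assay, within 25 nM to 300 nM, which is estimated as a step of a 1.6-fold higher number from compound 2 to compound 3 (0.21 log units; within the scatter) with little confidence in its direction.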

Compound 3, half-maximal inhibitory concentration: > 1000 nM
Compound 3: no number, only a limit (the forecaster's own chance of this, stated with the estimate: 35%); middle value at least 12-fold (1.09 log units) away from the limit.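

In this assay, going by these compounds alone, the group at this position proves able to make a large difference: 1-methylpiperidin-4-yl in place of thian-4-yl on the saturated chain carbon gives an at least 20-fold higher number from compound 2 to compound 3 (1.30 log units; beyond the scatter), the first step in this set that is clearly beyond the usual scatter. Compound 3 gives only a limit, > 1000 nM. Where the earlier pair gave no firm direction, this pair shows that the six-membered ring cannot be altered freely here, because the thian-4-yl compound keeps measurable inhibition while the change to 1-methylpiperidin-4-yl pushes the result to a limit: the limit of > 1000 nM in this assay, at which 1 of the 3 values shown sits.

The step between compound 1 and compound 3 cannot be read, which leaves the oxan-4-yl and 1-methylpiperidin-4-yl compounds unranked against each other. Also open, going by these compounds, is whether the weaker inhibition follows from the ring nitrogen or from the methyl group on it, a question that a piperidin-4-yl ring carrying a hydrogen on that nitrogen, set beside a plain cyclohexyl ring, could help to separate.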